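Cyclopentyl Amide in Place of the Difluoropropyl Amide

A few compounds are considered here, and "the series" means these few. Any claim that something is new, unique, unknown or untested is made for them only; others in the source may bear on it.

compound 1 `Cc1nc(S(C)(=O)=O)ccc1Oc1ncnc(OC2CCN(C(=O)O[C@H](C)CF)CC2)c1F` — 1520 nM
compound 2 `Cc1nc(S(C)(=O)=O)ccc1Oc1ncnc(OC2CCN(C(=O)C(F)(F)F)CC2)c1F` — 880 nM
compound 3 `CCC(F)(F)C(=O)N1CCC(Oc2ncnc(Oc3ccc(S(C)(=O)=O)nc3C)c2F)CC1` — 69.2 nM

The three compounds above were measured in a functional assay on isolated protein for inhibition of Glucose-dependent insulinotropic receptor (Rattus norvegicus), read by HTRF and cAMP accumulation; on this read-out higher numbers stand for an effect only at larger amounts of compound and lower numbers for an effect already at smaller amounts. Compound 3 stands lowest of the three numbers: the step of a 13-fold lower number from compound 2 to compound 3 (1.10 log units; beyond the scatter) and the step of a 22-fold lower number from compound 1 to compound 3 (1.34 log units; beyond the scatter) are both beyond the scatter, whereas a 1.7-fold lower number from compound 1 to compound 2 (0.24 log units; within the scatter) lies within it. Compound 4 `Cc1nc(S(C)(=O)=O)ccc1Oc1ncnc(OC2CCN(C(=O)C3CCCC3)CC2)c1F` is not yet measured; it differs from compound 3 by cyclopentyl in place of 1,1-difluoropropyl on a carbonyl carbon. Both large steps concern the same carbonyl carbon, and the step from compound 2 to compound 3 shows that adding carbon there lowered the number. Cyclopentyl carries no fluorine, so some loss is expected. The step expected for compound 4 is a 2.2-fold higher number from compound 3 to compound 4 (0.34 log units; beyond the scatter). Compound 4 is estimated at 150 nM, between 40 nM and 600 nM.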

Compound 4, half-maximal effective concentration: 407 nM
Compound 4: the middle estimate sits 2.7-fold (0.43 log units) below what was measured, within the range that was stated.
By their numbers in this assay, from the lowest: compound 3; then compound 4; then compounds 2 and 1 (each within the scatter of the next).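

In this assay, cyclopentyl on the carbonyl carbon gives up ground to 1,1-difluoropropyl, with a 5.9-fold higher number from compound 3 to compound 4 (0.77 log units; beyond the scatter), yet it still improves on trifluoromethyl, with a 2.2-fold lower number from compound 2 to compound 4 (0.33 log units; beyond the scatter), and on the group of compound 1, with a 3.7-fold lower number from compound 1 to compound 4 (0.57 log units; beyond the scatter). A group of carbon only can thus give a lower number than two fluorine-bearing groups, so fluorine content alone does not order this position, and compounds 1 and 2 go against any such rule. Nothing available explains these steps. On these data alone, a plain propyl chain would separate the effect of the ring from that of the fluorine atoms, and this remains open. As far as these compounds go, how cyclobutyl or phenyl would compare at this carbonyl carbon also remains open.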